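Butyl in Place of the Azido-Hydroxypropyl Chain

This account rests on a few compounds, and the source may have more. Where it says the series, first, only, none or still open, it means among the compounds named here.

Two measured compounds frame this account. Compound 1 `[N-]=[N+]=NCC(O)Cn1c(=O)n(C2OC(CO)[C@@H](O)[C@H]2O)c2nc(N)nc(O)c21` gives 39 uM in a functional assay (B cells) with Mus musculus as the target (on this read-out higher numbers stand for an effect only at larger amounts of compound and lower numbers for an effect already at smaller amounts), and this is the lowest of the two numbers recorded so far. Compound 2 `CCCn1c(=O)n(C2CCC(COC(C)=O)O2)c2nc(NC(C)=O)nc(O)c21` differs from compound 1 in several places at once; in this assay compound 2 gives 154 uM, a number that lies beyond the scatter above that of compound 1. Since the two differ in more than one place, only their values, not a single step, can be compared.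

The unmeasured compound 3 `CCCCn1c(=O)n(C2OC(CO)[C@@H](O)[C@H]2O)c2nc(N)nc(O)c21` keeps the core and the sugar of compound 1 and alters only the chain on the aromatic nitrogen: propyl in place of 2-azido-1-hydroxyethyl on a saturated chain carbon bound to an aromatic nitrogen. The chain that enters carries neither a hydrogen-bond donor nor an acceptor, where the chain that leaves carried both.

Because compound 2, which also carries a plain propyl on that nitrogen, gives 154 uM, the author expects the step from compound 1 to compound 3 in this assay to run toward a modestly higher number, a 1.5-fold higher number from compound 1 to compound 3 (0.19 log units; within the scatter), possibly still within the scatter. For compound 3 the estimated value in this assay is 60 uM, with an expected range from 20 uM to 180 uM.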

Compound 3, concentration for half-maximal effect: 11 uM
The estimate for compound 3 lay 5.5-fold (0.74 log units) above the measured number; the whole stated range lies above it.
By their numbers in this assay, from the lowest: compound 3; then compound 1; then compound 2.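

In this assay, within the data shown here, the exchange of 2-azido-1-hydroxyethyl for propyl, on a saturated chain carbon bound to an aromatic nitrogen, gives a 3.5-fold lower number from compound 1 to compound 3 (0.55 log units; beyond the scatter) with the core and the sugar left unchanged, and this is the first step that speaks to this position alone. It shows that neither the azido group nor the hydroxyl of the leaving chain is required to reach this level, since a plain propyl with 0 hydrogen-bond donors and 0 hydrogen-bond acceptors is accepted here and the effect appears at a smaller amount of compound. No measurement shown here bears on the reason for this step.

This one step removes the azido group and the hydroxyl together, so it cannot tell which of the two losses matters, and a chain keeping only one of them, such as a 2-hydroxybutyl or a 4-azidobutyl, would separate them. From the compounds shown here alone, how far the trend runs along the chain also remains open, as a longer chain such as hexyl or a shorter one such as ethyl could show.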